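Trifluoromethyl in Place of Fluoro: an Expected Step

This account rests on a few compounds, and the source may have more. Where it says the series, first, only, none or still open, it means among the compounds named here.

Of the compounds shown here, three sharing one core have been measured in a functional assay on HCT-15 cells (Homo sapiens) for inhibition; a higher number here means a weaker inhibitor, a lower number a stronger inhibitor. Compound 1 `Oc1cccc(-c2cc(-c3cccc(F)c3)cc(-c3ccccc3O)n2)c1` gives only a limit in this assay, > 50000 nM. Compound 2 `Oc1cccc(-c2cc(-c3cccc(F)c3)cc(-c3cccc(O)c3)n2)c1` gives 7860 nM in this assay, the highest of the two numbers shown, and compound 3 `Oc1ccc(-c2cc(-c3cccc(F)c3)cc(-c3cccc(O)c3)n2)cc1` gives 3070 nM. All measured steps concern the hydroxyphenyl groups: an at least 6.3-fold lower number from compound 1 to compound 2 (0.80 log units; beyond the scatter), an at least 16-fold lower number from compound 1 to compound 3 (1.21 log units; beyond the scatter) and a 2.6-fold lower number from compound 2 to compound 3 (0.41 log units; beyond the scatter).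

Compound 4 `Oc1cccc(-c2cc(-c3cccc(C(F)(F)F)c3)cc(-c3cccc(O)c3)n2)c1` differs from compound 2 in another place: trifluoromethyl in place of fluoro on an aromatic carbon. None of the measured steps touches this fluorophenyl group, so they give no direction for the change, and nothing shown allows a property to be assigned to the trifluoromethyl group. Within the data shown here, with no bearing step, the expected step in this assay is a 1.0-fold lower number from compound 2 to compound 4 (0.00 log units; within the scatter), which lies within the usual scatter. Compound 4 is therefore estimated at 7800 nM in this assay, with a range from 2500 nM to 25000 nM.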

Compound 4, half-maximal inhibitory concentration: 13600 nM
For compound 4 the middle estimate is 1.7-fold (0.24 log units) below the measured one; measured number inside the range.
By their numbers in this assay, from the lowest: compound 3; then compounds 2 and 4 (each within the scatter of the next). At a limit, above all of these: compound 1.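

In this assay, among these compounds, compound 2 and compound 4 cannot be told apart, and this is the first measured change at the fluorophenyl group: a 1.7-fold higher number from compound 2 to compound 4 (0.24 log units; within the scatter). Among the compounds shown here, at this place, meta to a large group, trifluoromethyl with its 4 heavy atoms stands in for fluoro with its 1 heavy atom without a step beyond the scatter, whereas all the earlier steps, which concern the hydroxyphenyl groups, lie beyond it. Nothing shown gives a cause for this outcome.

The compounds shown leave open whether an amine, a carboxylic acid or a longer chain at this place would also stay within the scatter of compound 2. They also leave open whether 3-(trifluoromethyl)phenyl would behave in the same way alongside the 4-hydroxyphenyl group of compound 3.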